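The source may hold more compounds than are shown below. What is called first, only, known or untested is meant among the compounds shown, and "the series" means these compounds.

Measured compounds:
- compound 1 `Cc1ccc(C)c(S(=O)(=O)N(C)/N=C/c2cnn3ccc(C#N)cc23)c1`: in an assay on isolated protein for inhibition of phosphatidylinositol 4,5-bisphosphate 3-kinase catalytic subunit beta isoform (Homo sapiens), read by 33P incorporation, with a stated time of 60 min (on this read-out lower numbers stand for stronger inhibition and higher numbers for weaker inhibition), compound 1 gives only a limit, > 1000 nM
- compound 2 `Cc1ccccc1S(=O)(=O)N(C)/N=C/c1cnn2ccc(C#N)cc12`: in this assay compound 2 gives only a limit, > 1000 nM

Compound 2 thus stands at the limit of the read-out, with no number behind it; the same holds for compound 1, so both sit at the limit of > 1000 nM in this assay, at which 2 of the 2 values shown sit. Among the compounds with values here, the one measured step, hydrogen in place of methyl on an aromatic carbon, is a step that the two limits leave unreadable from compound 1 to compound 2.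

Compound 3 `CC(=O)Nc1ccc(C)c(S(=O)(=O)N(C)/N=C/c2cnn3ccc(C#N)cc23)c1` is not yet measured. It differs from compound 2 by acetamido in place of hydrogen on an aromatic carbon. Within the data shown here, no measured step bears on an acetamido group, and the single step from compound 1 to compound 2 is unreadable because the limit of > 1000 nM in this assay, at which 2 of the 2 values shown sit, holds both values. Among the measured compounds shown here, no direction beyond the scatter can therefore be expected; the series so far gives only limits.

Compound 3 is estimated at 1500 nM, between 400 nM and 6000 nM, which means an expected step that the limit leaves unreadable from compound 2 to compound 3.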

Compound 3, half-maximal inhibitory concentration: > 1000 nM
Compound 3: only a limit was reported (the forecaster's own chance of this, stated with the estimate: 60%); the middle value lies beyond the limit too.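

In this assay compound 3 gives only a limit, > 1000 nM. Within the data shown here, no step among compound 1, compound 2 and compound 3 can be read: the limit of > 1000 nM in this assay, at which 3 of the 3 values shown sit. The compounds shown leave open how strongly any of the three inhibits, and whether acetamido in place of hydrogen changes inhibition at all.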